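This account rests on a few compounds, and the source may have more. Where it says the series, first, only, none or still open, it means among the compounds named here.

In a functional assay on K562 cells (Homo sapiens) for cytotoxicity, read by trypan blue exclusion, with a stated time of 96 h (a higher number here means a weaker inhibitor, a lower number a stronger inhibitor), compound 1 (`COc1ccc(N)cc1CS(=O)(=O)/C=C/c1c(OC)cccc1OC`) gives 25000 nM and compound 2 (`COc1cc(OC)c(/C=C/S(=O)(=O)Cc2ccc(OC)c([N+](=O)[O-])c2)c(OC)c1`) gives 2500 nM while compound 3 (`COC(=O)[C@H](C)Nc1cc(CS(=O)(=O)/C=C/c2c(OC)cc(OC)cc2OC)ccc1OC`) gives 200 nM as the lowest of the three numbers. Compound 4 (`COC(=O)C(Nc1cc(CS(=O)(=O)/C=C/c2c(OC)cc(OC)cc2OC)ccc1OC)c1ccc(F)cc1`) is still unmeasured and carries (4-fluorophenyl)(methoxycarbonyl)methyl in place of 1-(methoxycarbonyl)ethyl on a nitrogen on an aromatic ring. For the measured compounds named here, the only measured step that bears on this is a 13-fold lower number from compound 2 to compound 3 (1.10 log units; beyond the scatter) and it is large, but it replaced nitro and does not vary the group now exchanged. No direction can be drawn from it, so no step beyond the scatter is expected in this assay here. The estimate amounts to a 1.3-fold higher number from compound 3 to compound 4 (0.10 log units; within the scatter) as the expected step. For compound 4 the expected value is 250 nM with an estimated range from 60 nM to 1000 nM around it.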

Compound 4, half-maximal inhibitory concentration: 800 nM
The estimate for compound 4 lay 3.2-fold (0.51 log units) below the measured number; low and high end bracket the measured number.
By their numbers in this assay, from the lowest: compound 3; then compound 4; then compound 2; then compound 1.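

The group on the nitrogen on an aromatic ring is varied directly here: (4-fluorophenyl)(methoxycarbonyl)methyl in place of 1-(methoxycarbonyl)ethyl gives a 4.0-fold higher number from compound 3 to compound 4 (0.60 log units; beyond the scatter) in this assay. The position therefore accepts a group carrying a six-membered aromatic ring at a modest cost, while this single pair does not establish a trend. No available evidence accounts for the step.

The compounds shown leave open whether the step follows from the added ring, the fluorine or the loss of the defined stereocentre. Also open, as far as these compounds go, is how a carboxylic acid in place of the methoxycarbonyl group would read here.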